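The source may report more compounds than this note shows. Statements on the series, on what has been measured and on what is new or still open speak of the compounds shown alone.

Within the data shown here, compound 2 `COc1ccc(C(=O)/C=C/c2cc(-c3cc(OC)c(OC)c(OC)c3)n[nH]2)cc1OC` gives -93% in a functional assay on LOX IMVI cells (Homo sapiens) for cytotoxicity, read by sulforhodamine B assay, with a stated time of 48 h, tested at 10 uM (a lower number here means a stronger effect, a higher number a weaker effect of the compound at the concentration tested), the lowest of the two numbers measured so far; compound 1 `COc1cc(-c2cc(/C=C/C(=O)c3ccc(N)cc3)[nH]n2)cc(OC)c1OC` gives -78%. Among the measured compounds shown here, the only measured step, a number 15 percentage points lower from compound 1 to compound 2 (beyond the scatter), places 3,4-dimethoxyphenyl in place of 4-aminophenyl on a carbonyl carbon. Compound 3 `COc1cc(C(=O)/C=C/c2cc(-c3cc(OC)c(OC)c(OC)c3)n[nH]2)cc(OC)c1OC` differs from compound 2 by methoxy in place of hydrogen on an aromatic carbon. No measured step carries this same change, so nothing shown bears directly on it, and no step beyond the usual scatter is expected. Compound 3 is therefore estimated at -90%, between -100% and -75%, with an expected step of a number 3 percentage points higher from compound 2 to compound 3 (within the scatter).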

Compound 3, a percentage reported as activity, at one concentration (the size of the read-out at that concentration, not a potency): -95%
Estimate against measurement, compound 3: 5 percentage points above, within the range that was stated.
By their numbers in this assay, from the lowest: compounds 3 and 2 (each within the scatter of the next); then compound 1.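

In this assay, methoxy in place of hydrogen on an aromatic carbon, ortho to a methoxy group, gives a number 2 percentage points lower from compound 2 to compound 3 (within the scatter) and so leaves the read-out unchanged within the scatter. This position therefore accepts the added methoxy without a measurable loss of effect at the concentration tested, and the two compounds cannot be ranked against each other. Nothing measured here gives a reason for this result. On these data alone, whether the same position would also accept a longer chain such as ethoxy, or an amine or a carboxylic acid, remains open.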